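Same Ester Change Repeated on a Second Core

The source may hold more compounds than are shown below. What is called first, only, known or untested is meant among the compounds shown, and "the series" means these compounds.

Compound 1 `CC1=C(C(=O)OCC(C)C)C(c2ccco2)NC(=S)N1` and compound 2 `CC1=C(C(=O)OC(C)(C)C)C(c2ccco2)NC(=S)N1` share one core; compound 3 `CC1=C(C(=O)OCC(C)C)C(c2ccco2)NC(=O)N1C` and compound 4 `CC1=C(C(=O)OC(C)(C)C)C(c2ccco2)NC(=O)N1C` share another, and the difference between the two cores is not broken down here. In an assay on membranes from CHO cells for displacement of a labelled ligand from adenosine receptor A1 (Homo sapiens), read by scintillation counting, with a stated time of 60 min, tested at 1 uM (a lower number here means less inhibition, a higher number more inhibition at the concentration tested (going by the name of the read-out)), compound 1 gives 7%, and compound 2 gives 3%. Compound 3 gives 13% in this assay. The change tert-butyl in place of isobutyl on an oxygen next to a carbonyl group made a number 4 percentage points lower from compound 1 to compound 2 (within the scatter). The same change, (tert-butyl in place of isobutyl on an oxygen next to a carbonyl group), leads from compound 3 to compound 4, which has not been measured in this assay. Resting on the step of a number 4 percentage points lower from compound 1 to compound 2 (within the scatter), compound 4 is expected to follow with a number 4 percentage points lower from compound 3 to compound 4 (within the scatter). Compound 4 is therefore estimated to give 9% in this assay, with an expected range from 0% to 20%.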

Compound 4, a percentage reported as inhibition, at one concentration (the size of the read-out at that concentration, not a potency): 44%
Estimate against measurement, compound 4: 35 percentage points below; the measured number lies above the stated range.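

In this assay, tert-butyl in place of isobutyl on an oxygen next to a carbonyl group gave a number 31 percentage points higher from compound 3 to compound 4 (beyond the scatter), so the change did not carry over from one core to the other: the same change on two cores in this assay, a number 4 percentage points lower (within the scatter) from compound 1 to compound 2 and a number 31 percentage points higher (beyond the scatter) from compound 3 to compound 4, 35 percentage points apart, beyond the scatter of two such steps

In this series, then, a step read on one core is no safe guide to the same change on the other. These two pairs do not show which feature of the cores separates the outcomes, nor why they part, and they rest on a single tested concentration.

As far as these compounds go, it remains open how a longer chain, a methyl ester or a carboxylic acid in that place would behave on either core. Also open, from the compounds shown here alone, is whether the rise seen with compound 4 would extend to such groups.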